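Three measured analogues and an expected fourth

The compounds below may be only part of what the source reports. "The series", "measured", "known", "first", "only" and "open" are said of these compounds alone.

Compound 1 `NC(=O)c1c(NC(=O)c2ccccc2Br)sc2c1CCN(C(=S)Nc1ccccc1Cl)C2`: 12900 nM
Compound 2 `COc1ccccc1C(=O)Nc1sc2c(c1C(N)=O)CCN(C(=S)Nc1ccccc1Cl)C2`: 20500 nM
Compound 3 `CSc1ccccc1C(=O)Nc1sc2c(c1C(N)=O)CCN(C(=S)Nc1ccccc1Cl)C2`: 6550 nM

In a functional assay on MKN-74 cells (Homo sapiens) for antiproliferative activity, with a stated time of 24 h (a lower number here means a stronger inhibitor, a higher number a weaker inhibitor), these three compounds share one core and differ only in the group attached to the carbonyl carbon of the amide. Compound 3 gives the lowest number of the three. Its step to compound 2 is beyond the scatter (a 3.1-fold lower number from compound 2 to compound 3 (0.50 log units; beyond the scatter)), whereas its step from compound 1 is not (a 2.0-fold lower number from compound 1 to compound 3 (0.29 log units; within the scatter)), and the step from compound 1 to compound 2 is also within the scatter (a 1.6-fold higher number from compound 1 to compound 2 (0.20 log units; within the scatter)). So compound 3 is separated clearly only from compound 2.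

Compound 4 `NC(=O)c1c(NC(=O)c2cccc([N+](=O)[O-])c2)sc2c1CCN(C(=S)Nc1ccccc1Cl)C2` carries the change (3-nitrophenyl in place of 2-(methylsulfanyl)phenyl on a carbonyl carbon). Among the measured compounds shown here, none of the measured steps covers a nitro group, nor a change in where the substituent sits on the ring; the three steps only show that swapping the substituent on this ring moves the number across a modest span, from the value of compound 3 to that of compound 2. On that basis a small shift toward a higher number is expected for compound 4, a 2.0-fold higher number from compound 3 to compound 4 (0.30 log units; within the scatter), which would place it near compound 1. Compound 4 is therefore estimated at 13000 nM in this assay, with a range from 4500 nM to 40000 nM.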

Compound 4, half-maximal inhibitory concentration: 8850 nM
Compound 4: the middle estimate sits 1.5-fold (0.17 log units) above what was measured, and the stated range covers the measured number.
By their numbers in this assay, from the lowest: compounds 3, 4, 1 and 2 (each within the scatter of the next, the first and the last beyond it).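

In this assay, the 3-nitrophenyl group of compound 4 brings both a new substituent and a new place on the ring, yet the result remains within the scatter of the 2-(methylsulfanyl)phenyl group, a 1.4-fold higher number from compound 3 to compound 4 (0.13 log units; within the scatter), and of the 2-bromophenyl group, a 1.5-fold lower number from compound 1 to compound 4 (0.16 log units; within the scatter). Only the comparison with the 2-methoxyphenyl group goes beyond the scatter, a 2.3-fold lower number from compound 2 to compound 4 (0.36 log units; beyond the scatter), so compound 2 now stands apart from both compound 3 and compound 4, though not from compound 1, and the overall span of the series stays at a 3.1-fold lower number from compound 2 to compound 3 (0.50 log units; beyond the scatter). No measurement offered here accounts for these differences.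

Because the nitro group and the changed place on the ring enter together, the compounds shown cannot say what each contributes on its own, or whether the two effects offset one another. They also leave open how the number would respond to an amine or a carboxylic acid on this ring, or to a longer chain on the carbonyl carbon in place of the aromatic ring.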